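This account rests on a few compounds, and the source may have more. Where it says the series, first, only, none or still open, it means among the compounds named here.

Measured in an assay on LtK cells with ATP-sensitive inward rectifier potassium channel 11 (Homo sapiens) as the target; on this read-out higher numbers stand for an effect only at larger amounts of compound and lower numbers for an effect already at smaller amounts:
compound 1 `CCC(C)C(=O)Nc1c(C(O)(C(F)(F)F)C(F)(F)F)ccc2ccccc12` gives 177000 nM
compound 2 `CC(C)CCC(=O)Nc1c(C(O)(C(F)(F)F)C(F)(F)F)ccc2ccccc12` gives 49 nM

For the measured compounds named here, compound 2 holds the lower of the two numbers in this assay; its only neighbour is compound 1, and the single measured step, a 3600-fold lower number from compound 1 to compound 2 (3.56 log units; beyond the scatter), is large. Compound 3 `O=C(Nc1ccc(Cl)cc1)Nc1c(C(O)(C(F)(F)F)C(F)(F)F)ccc2ccccc12` is not yet measured. It differs from compound 2 by (4-chlorophenyl)amino in place of isopentyl on a carbonyl carbon. Going by the values given here, no measured step covers a change of this kind; the one step available, also on the carbonyl carbon, was large, so a sizeable step in either direction cannot be ruled out. For compound 3 a higher number than for compound 2 is expected, a 16-fold higher number from compound 2 to compound 3 (1.21 log units; beyond the scatter), with an estimate of 800 nM and a range from 30 nM to 20000 nM.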

Compound 3, half-maximal effective concentration: 276 nM
Estimate against measurement, compound 3: 2.9-fold (0.46 log units) above; the range from low to high includes it.
By their numbers in this assay, from the lowest: compound 2; then compound 3; then compound 1.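

In this assay the carbonyl carbon tolerates more than branched or unbranched alkyl groups: (4-chlorophenyl)amino, with its aromatic ring and hydrogen-bond donor, costs only a 5.6-fold higher number from compound 2 to compound 3 (0.75 log units; beyond the scatter) against isopentyl, and it still gives a 640-fold lower number from compound 1 to compound 3 (2.81 log units; beyond the scatter) against sec-butyl. A low number at this position therefore does not depend on isopentyl alone. No evidence bears on the reason for either step.

From the compounds shown here alone, what remains open is whether the chlorine or the nitrogen matters here. Phenylamino and 4-chlorobenzyl on the same carbonyl carbon would separate the two.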